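Growing the Amine Substituents One Carbon at a Time

The compounds below may be only part of what the source reports. "The series", "measured", "known", "first", "only" and "open" are said of these compounds alone.

Two measured compounds share one core. Compound 1 `CN(C)CCCOc1ccc(C(=O)/C=C/c2ccccc2)cc1` gives 1.59 in a physicochemical assay for lipophilicity, using the shake flask method, measured as octanol-water partition, at pH 7.4; a higher number here means a more lipophilic compound, a lower number a more polar compound. Compound 2 `CCN(CC)CCCCOc1ccc(C(=O)/C=C/c2ccccc2)cc1` gives 1.74 in this assay, and the gap between the two is small: a number 0.15 log units higher from compound 1 to compound 2 (within the scatter). Compound 3 `CCCN(CCC)CCCCOc1ccc(C(=O)/C=C/c2ccccc2)cc1` differs from compound 2 by dipropylamino in place of diethylamino on a saturated chain carbon, four bonds along the chain from an oxygen on an aromatic ring. Within the data shown here, the one measured step enlarged the same amine, so it is the only guide here. A rise of similar or somewhat larger size is expected for compound 3, namely a number 0.46 log units higher from compound 2 to compound 3 (beyond the scatter), because a number 0.15 log units higher from compound 1 to compound 2 (within the scatter) already pointed upward. Compound 3 is therefore estimated at 2.2, with a range from 1.8 to 2.7.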

Compound 3, partition coefficient: 1.95
Compound 3: the middle estimate sits 0.25 log units above what was measured; the measured number falls inside the stated range.
By their numbers in this assay, from the lowest: compounds 1, 2 and 3 (each within the scatter of the next, the first and the last beyond it).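

Putting dipropylamino in place of diethylamino gives a number 0.21 log units higher from compound 2 to compound 3 (within the scatter) in this assay, so this single enlargement of the amine cannot be told apart from the ordinary spread of repeated measurements. Across the series as a whole, the change gives a number 0.36 log units higher from compound 1 to compound 3 (beyond the scatter), the first gap here that clears that spread, although neither single step does. No measurement at hand accounts for these numbers.

Still open, from the compounds shown here alone, is how a larger amine such as dibutylamino would read in this assay. A ring amine such as piperidine, carried on the same chain, is also left open.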